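Amide for acid on two related cores: a small step

The compounds below may be only part of what the source reports. "The series", "measured", "known", "first", "only" and "open" are said of these compounds alone.

Measured compounds:
- Compound 1, `CNC(=O)/C=C/c1ccncc1-c1ccc2ccccc2c1`, gives 9340 nM in a functional assay on MCF7 cells (Homo sapiens) for inhibition, read by sulforhodamine B assay, with a stated time of 72 h; on this read-out lower numbers stand for stronger inhibition of growth and higher numbers for weaker inhibition of growth.
- Compound 2, `O=C(O)/C=C/c1ccncc1-c1ccc2ccccc2c1`, reaches only the limit of this assay, reported as > 10000 nM.
- Compound 3, `Cn1ncc2cc(-c3cnccc3/C=C/C(=O)O)ccc21`, also reaches only the limit of this assay, reported as > 10000 nM.

Compound 2 and compound 1 share one core and differ in one place: methylamino in place of hydroxy on a carbonyl carbon. Both compounds sit near the edge of what this assay can report, so the step is small: an at least 1.0-fold lower number from compound 2 to compound 1 (0.02 log units; that floor lies within the scatter). Because the limit of > 10000 nM in this assay, at which 2 of the 3 values shown sit, holds two of the three values, the true size of that step cannot be pinned down more closely.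

Compound 3 carries a different core from compound 2; the difference between the two cores is not broken down here. Compound 4, `CNC(=O)/C=C/c1ccncc1-c1ccc2c(cnn2C)c1`, has not yet been measured. It stands to compound 3 exactly as compound 1 stands to compound 2, the same change made on the other core: methylamino in place of hydroxy on a carbonyl carbon.

For compound 4 the expectation rests on the earlier step, which was small and sat within the scatter, and on the limit reached by compound 3 at > 10000 nM. Compound 4 is therefore expected to land near the limit again, with a step estimated at a step that the limit leaves unreadable from compound 3 to compound 4. The estimate for compound 4 in this assay is 12000 nM, expected between 5000 nM and 30000 nM.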

Compound 4, concentration for 50% growth inhibition: > 10000 nM
Compound 4: no number, only a limit; the forecaster's own chance of this, stated with the estimate: 55%; the middle value is on the limit's open side.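

In this assay compound 4 gives only a limit, > 10000 nM, and not a number. Compound 3 also stands at a limit, so no step from compound 3 to compound 4 can be read: the limit of > 10000 nM in this assay, at which 3 of the 4 values shown sit.

The compounds shown leave open how far compound 3 and compound 4 really lie past that limit, and whether methylamino in place of hydroxy changes growth inhibition on this core at all.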